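Bicyclic sulfonamide series: chlorinated variant of compound 3

The compounds below may be only part of what the source reports. "The series", "measured", "known", "first", "only" and "open" are said of these compounds alone.

Compound 3 `O=C1[C@@H](NS(=O)(=O)c2cc3cccnc3s2)CCN1Cc1cc2c[nH]ccc-2n1` stands lowest of the three numbers measured in an assay on isolated protein for inhibition of coagulation factor X (Oryctolagus cuniculus), tested at 1 uM; on this read-out lower numbers stand for less inhibition and higher numbers for more inhibition at the one concentration tested (going by the name of the read-out); in this assay compound 3 gives 18%. Compound 2 `O=C1[C@@H](NS(=O)(=O)c2cc3ccnc(Cl)c3s2)CCN1Cc1cc2c[nH]ccc-2n1` gives 25%, and the step of a number 7 percentage points lower from compound 2 to compound 3 (within the scatter) is within the scatter. Compound 1 `O=C1[C@@H](NS(=O)(=O)c2cc3ncccc3s2)CCN1Cc1cc2c[nH]ccc-2n1` gives 61%, and the step of a number 43 percentage points lower from compound 1 to compound 3 (beyond the scatter) is large.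

Compound 4 `O=C1[C@@H](NS(=O)(=O)c2cc3nc(Cl)ccc3s2)CCN1Cc1cc2c[nH]ccc-2n1` differs from compound 3 as follows: a group of 10 heavy atoms (7 carbon, 1 nitrogen, 1 sulfur, 1 chlorine; one five-membered aromatic ring with 1 hetero atom, one six-membered aromatic ring with 1 hetero atom) in place of a group of 9 heavy atoms (7 carbon, 1 nitrogen, 1 sulfur; one five-membered aromatic ring with 1 hetero atom, one six-membered aromatic ring with 1 hetero atom), on a sulfonyl sulfur. Apart from the chlorine, the group entering in compound 4 is the group carried by compound 1, so the measured steps that bear on this change are a number 43 percentage points lower from compound 1 to compound 3 (beyond the scatter), which is large, and a number 36 percentage points lower from compound 1 to compound 2 (beyond the scatter), also large, where a chlorine-bearing group replaced the group of compound 1. The step of a number 7 percentage points lower from compound 2 to compound 3 (within the scatter) suggests the two chlorine-free and chlorine-bearing groups other than that of compound 1 sit close together.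

Within the data shown here, the change from compound 3 to compound 4 therefore pulls back toward the ring arrangement of compound 1, while the chlorine is the part for which no clean step is known. A rise is expected, with the step of a number 27 percentage points higher from compound 3 to compound 4 (beyond the scatter) estimated as beyond the scatter but short of the number for compound 1 because a number 36 percentage points lower from compound 1 to compound 2 (beyond the scatter) was accompanied by a chlorine. Compound 4 is expected to give about 45%, in the range 22% to 68%.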

Compound 4, a percentage reported as inhibition, at one concentration (the size of the read-out at that concentration, not a potency): 58%
Beside the measured number, compound 4's estimate is 13 percentage points below it; the range from low to high includes it.
By their numbers in this assay, from the lowest: compounds 3 and 2 (each within the scatter of the next); then compounds 4 and 1 (each within the scatter of the next).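

In this assay the step of a number 3 percentage points lower from compound 1 to compound 4 (within the scatter) gives the first clean read on chloro in place of hydrogen on an aromatic carbon: this group on the sulfonyl sulfur accepts the chlorine with no change beyond the scatter. The series also shows a number 40 percentage points higher from compound 3 to compound 4 (beyond the scatter) and a number 33 percentage points higher from compound 2 to compound 4 (beyond the scatter) as two large steps, and since the second joins two chlorine-bearing groups, the presence of chlorine alone does not set the number here, while the arrangement of atoms within the group tracks with it across these four compounds. No measurement at hand accounts for these differences.

The compounds shown leave open whether methoxy, an amine or a nitrile in place of the chloro would hold the number as chloro does, and whether chloro on the group of compound 3 would leave that low number unchanged. Since every number is a percentage at one concentration, they also leave open how compound 1 and compound 4 compare as full potencies, which a concentration series would settle.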